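Compound 4 and the swap to quinolin-3-yl

This account rests on a few compounds, and the source may have more. Where it says the series, first, only, none or still open, it means among the compounds named here.

Compound 1 `Cn1c(=O)c(S(=O)(=O)c2ccc(Cl)cc2)cc2cnc(Nc3ccc4[nH]ccc4c3)nc21`: 250 nM
Compound 2 `Cn1c(=O)c(S(=O)(=O)c2ccc(Cl)cc2)cc2cnc(Nc3cccc4[nH]ccc34)nc21`: 5000 nM
Compound 3 `Cn1c(=O)c(S(=O)(=O)c2ccc(Cl)cc2)cc2cnc(Nc3cnc4[nH]ccc4c3)nc21`: 5000 nM

In a functional assay on DU-145 cells (Homo sapiens) for inhibition, read by trypan blue exclusion, with a stated time of 72 h (on this read-out higher numbers stand for weaker inhibition and lower numbers for stronger inhibition), compound 3 gives 5000 nM, level with compound 2, and together they hold the highest of the three numbers. Compound 4 `Cn1c(=O)c(S(=O)(=O)c2ccc(Cl)cc2)cc2cnc(Nc3cnc4ccccc4c3)nc21` has yet to be measured. Its change from compound 3 is a group of 10 heavy atoms (9 carbon, 1 nitrogen; one six-membered aromatic ring of carbon only, one six-membered aromatic ring with 1 hetero atom) in place of a group of 9 heavy atoms (7 carbon, 2 nitrogen; one five-membered aromatic ring with 1 hetero atom, one six-membered aromatic ring with 1 hetero atom), on a nitrogen on an aromatic ring.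

Among the compounds with values here, three measured steps bear on this change, all at the same place on the nitrogen. Two were large: a 20-fold higher number from compound 1 to compound 2 (1.30 log units; beyond the scatter), with 1H-indol-4-yl in place of 1H-indol-5-yl, and a 20-fold higher number from compound 1 to compound 3 (1.30 log units; beyond the scatter). The third, no change at the digits printed from compound 2 to compound 3 (within the scatter), lay within the scatter. Within the data shown here, only compound 1 stands apart, and no measured compound carries quinolin-3-yl, so the data give little guide to direction. Starting from compound 3, no step beyond the scatter is expected, and the estimated step is a 1.7-fold lower number from compound 3 to compound 4 (0.22 log units; within the scatter). Compound 4 is estimated at 3000 nM in this assay, with an expected range of 800 nM to 10000 nM.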

Compound 4, half-maximal inhibitory concentration: 15000 nM
Compound 4: middle estimate off by 5.0-fold (0.70 log units), on the low side; measured number above the stated range.
By their numbers in this assay, from the lowest: compound 1; then compounds 2 and 3 (each within the scatter of the next); then compound 4.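

In this assay, quinolin-3-yl on a nitrogen on an aromatic ring gives a further rise over the two compounds that had stood level, with a 3.0-fold higher number from compound 3 to compound 4 (0.48 log units; beyond the scatter) and a 3.0-fold higher number from compound 2 to compound 4 (0.48 log units; beyond the scatter) as the steps, so this place still responds to change beyond the level those two share. The gap to the indol-5-yl parent is much wider, at a 60-fold higher number from compound 1 to compound 4 (1.78 log units; beyond the scatter), which leaves compound 4 as the weakest of the four and compound 1 still alone at the strong end. No measurement shown accounts for this shift.

The compounds leave open whether another fused group on this nitrogen, such as quinolin-6-yl or 1H-indazol-5-yl, would come back toward compound 1. They also leave open how a single aromatic ring carrying an amine or a carboxylic acid would fare at the same place.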